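Para-substituent variation on the aryl group of the shared core

The compounds below may be only part of what the source reports. "The series", "measured", "known", "first", "only" and "open" are said of these compounds alone.

Measured compounds:
- compound 1, `Cn1nc2c(=O)n(CC3(O)CCN(Cc4ccc(-c5ccco5)cc4Cl)CC3)cnc2c1-c1ccc(CO)cc1`: 42.5 nM
- compound 2, `CC(=O)NCc1ccc(-c2c3ncn(CC4(O)CCN(Cc5ccc(-c6ccco6)cc5Cl)CC4)c(=O)c3nn2C)cc1`: 46.1 nM
- compound 3, `Cn1nc2c(=O)n(CC3(O)CCN(Cc4ccc(-c5ccco5)cc4Cl)CC3)cnc2c1-c1ccc(C(N)=O)cc1`: 80.8 nM

Three compounds share the core of compound 1 and differ only in the group on the pendant six-membered aromatic ring. In an assay on isolated protein for inhibition of ubiquitin carboxyl-terminal hydrolase 7 (Homo sapiens), with stated times of 30 min and 2 h (a lower number here means a stronger inhibitor, a higher number a weaker inhibitor), compound 1 gives 42.5 nM, compound 2 gives 46.1 nM and compound 3 gives 80.8 nM. Compound 3 carries the highest number of the three, but a 1.9-fold higher number from compound 1 to compound 3 (0.28 log units; within the scatter) and a 1.8-fold higher number from compound 2 to compound 3 (0.24 log units; within the scatter) are both within the scatter, as is a 1.1-fold higher number from compound 1 to compound 2 (0.04 log units; within the scatter); on these numbers the three are not distinguishable.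

Compound 4, `Cn1nc2c(=O)n(CC3(O)CCN(Cc4ccc(-c5ccco5)cc4Cl)CC3)cnc2c1-c1ccc(CNC2CC2)cc1`, continues the series at the same position: (cyclopropylamino)methyl in place of carbamoyl on an aromatic carbon. Within the data shown here, the steps that bear on this are the two into compound 3, hydroxymethyl to carbamoyl and acetamidomethyl to carbamoyl, neither of which moved the number beyond the scatter. Nothing measured here separates one group at this position from another, so no step beyond the scatter is expected in this assay for compound 4 either; if anything, compound 3 standing at the high end leaves a little room for a lower number.

Compound 4 is therefore expected at 55 nM, within 22 nM to 140 nM, an expected step of a 1.5-fold lower number from compound 3 to compound 4 (0.17 log units; within the scatter).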

Compound 4, half-maximal inhibitory concentration: 54.1 nM
The estimate for compound 4 lay 1.0-fold (0.01 log units) above the measured number; low and high end bracket the measured number.
By their numbers in this assay, from the lowest: compounds 1, 2, 4 and 3 (each within the scatter of the next).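

In this assay, among these compounds, the position on the pendant aromatic ring also accepts a group with a three-membered carbon ring and no oxygen, the first such group: (cyclopropylamino)methyl in place of carbamoyl stays within the scatter (a 1.5-fold lower number from compound 3 to compound 4 (0.17 log units; within the scatter)). The two further comparisons read the same way, with cyclopropyl in place of acetyl on the amine nitrogen (a 1.2-fold higher number from compound 2 to compound 4 (0.07 log units; within the scatter)) and cyclopropylamino in place of hydroxy (a 1.3-fold higher number from compound 1 to compound 4 (0.10 log units; within the scatter)), so neither loss of the carbonyl nor loss of the hydroxy oxygen separates compound 4 from its neighbours, and the four compounds remain a single group on these numbers. No supporting data bear on why this position shows no step beyond the scatter.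

The compounds shown leave open whether any group here can move the number beyond the scatter, since all four carry a single substituent of modest size at this place. A carboxylic acid, a tertiary amine such as a morpholinomethyl group, a longer chain ending in an amine, or a small group such as fluoro would test how far this tolerance extends.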